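Replacing the amide group of a very soluble compound

The source may report more compounds than this note shows. Statements on the series, on what has been measured and on what is new or still open speak of the compounds shown alone.

In a physicochemical assay for solubility, measured as thermodynamic solubility, with a stated time of 24 h, at pH 6.8 (a lower number here means a less soluble compound, a higher number a more soluble compound), compound 1 `Cc1cc(C)c2cc(C(=O)NC3CCN(C)CC3)[nH]c2c1` reads > 10000000 nM as a limit of the assay and not a number. Among the compounds with values here, that limit puts compound 1 at the top of the three compounds measured so far. Compound 2 `CCC(C)NC(=O)c1cc2c(C)cc(C)cc2[nH]1` gives 22000 nM in the same test. Compound 3 `Cc1cc(C)c2cc(C(=O)NC3CCCCCC3)[nH]c2c1` reads < 4000 nM as a limit as well.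

Compound 4 `Cc1cc(C)c2cc(C(=O)NC3CCOCC3)[nH]c2c1` has not yet been measured. It carries oxan-4-yl in place of 1-methylpiperidin-4-yl on an amide-type nitrogen and keeps the core of compound 1.

Within the data shown here, two measured steps bear most directly on this change, since each replaces the same 1-methylpiperidin-4-yl group. Sec-butyl gives an at least 450-fold lower number from compound 1 to compound 2 (2.65 log units; beyond the scatter) and cycloheptyl gives an at least 2500-fold lower number from compound 1 to compound 3 (3.39 log units; beyond the scatter) and both steps are large. The replacing group matters too, as cycloheptyl in place of sec-butyl gives an at least 5.5-fold lower number from compound 2 to compound 3 (0.74 log units; beyond the scatter) and that step is at least modest.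

A large step down in this assay is therefore expected for compound 4 as well. The estimated step is an at least 160-fold lower number from compound 1 to compound 4 (2.22 log units; beyond the scatter) on this reasoning. For compound 4 the expected value is 60000 nM with an estimated range from 15000 nM to 300000 nM as the likely span.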

Compound 4, solubility: 17000 nM
Compound 4: the middle estimate sits 3.5-fold (0.55 log units) above what was measured; the measured number falls inside the stated range.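

Keeping a six-membered non-aromatic ring with 1 hetero atom on the amide-type nitrogen does not preserve the reading of compound 1 in this assay, since oxan-4-yl in place of 1-methylpiperidin-4-yl gives an at least 580-fold lower number from compound 1 to compound 4 (2.76 log units; beyond the scatter), and the size of this step stays open at its upper end, as compound 1 reads only as a limit of the assay: the limit of > 10000000 nM in this assay, at which 1 of the 4 values shown sits. The ring oxygen of oxan-4-yl does still separate this compound from the all-carbon cycloheptyl ring, with an at least 4.2-fold higher number from compound 3 to compound 4 (0.62 log units; beyond the scatter), and here compound 3 reads only as a limit of the assay: the limit of < 4000 nM in this assay, at which 1 of the 4 values shown sits. The open-chain sec-butyl group and oxan-4-yl cannot be told apart, as a 1.3-fold lower number from compound 2 to compound 4 (0.11 log units; within the scatter) lies within the scatter, so among the groups shown only 1-methylpiperidin-4-yl stands far above the rest.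

The compounds shown leave open whether the ring nitrogen alone accounts for the reading of compound 1, or whether the methyl on it and the ring around it also play a part. A piperidin-4-yl ring without the methyl, or an open-chain amine such as 2-(dimethylamino)ethyl on the same amide-type nitrogen, would separate these possibilities.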